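Swapping the chloro-purine of compound 2 for a hydroxy-purine

The compounds below may be only part of what the source reports. "The series", "measured", "known", "first", "only" and "open" are said of these compounds alone.

The series is judged in a functional assay on MCF7 cells (Homo sapiens) for antiproliferative activity; a lower number here means a stronger inhibitor, a higher number a weaker inhibitor. Among the measured compounds shown here, compound 2 `O=[N+]([O-])c1ccccc1S(=O)(=O)N1CC(n2cnc3c(Cl)ncnc32)OCc2ccccc21` gives 2100 nM, the lowest of the three numbers known. Compound 1 `O=[N+]([O-])c1ccc(S(=O)(=O)N2CC(n3cnc4c(Cl)ncnc43)OCc3ccccc32)cc1` gives 2730 nM, and the step of a 1.3-fold lower number from compound 1 to compound 2 (0.11 log units; within the scatter) lies within the scatter, so the two cannot be ordered. Compound 3 `COC(CN(c1ccccc1CO)S(=O)(=O)c1ccc([N+](=O)[O-])cc1)n1c(=O)cc[nH]c1=O`, built on a different core, gives 55200 nM, which stands far above compound 2.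

Compound 4 `O=[N+]([O-])c1ccccc1S(=O)(=O)N1CC(n2cnc3ncnc(O)c32)OCc2ccccc21` has not yet been measured. It differs from compound 2 in one place: a group of 10 heavy atoms (5 carbon, 4 nitrogen, 1 oxygen; one five-membered aromatic ring with 2 hetero atoms, one six-membered aromatic ring with 2 hetero atoms) in place of a group of 10 heavy atoms (5 carbon, 4 nitrogen, 1 chlorine; one five-membered aromatic ring with 2 hetero atoms, one six-membered aromatic ring with 2 hetero atoms), on a saturated ring carbon. For the measured compounds named here, none of the measured steps touches this part of the molecule; the only step recorded, between compound 1 and compound 2, moves the nitro group on the sulfonyl aryl ring and says nothing about the purine. The expectation therefore rests on compound 2 alone, with a wide range. Going by the values given here, compound 4 is expected to give a somewhat higher number, an estimated step of a 2.4-fold higher number from compound 2 to compound 4 (0.38 log units; beyond the scatter), since the data give no step to anchor it. For compound 4 the estimate is 5000 nM, with a range from 1500 nM to 20000 nM.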

Compound 4, half-maximal inhibitory concentration: 19700 nM
Compound 4: the middle estimate sits 3.9-fold (0.60 log units) below what was measured, and the stated range covers the measured number.
By their numbers in this assay, from the lowest: compounds 2 and 1 (each within the scatter of the next); then compound 4; then compound 3.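

In this assay the group on the saturated ring carbon next to the ring oxygen proves sensitive to a single exchange of atoms: the hydroxy group in place of the chlorine gives a 9.4-fold higher number from compound 2 to compound 4 (0.97 log units; beyond the scatter) and so exceeds the scatter. Among the compounds shown here, the earlier pair, at a 1.3-fold lower number from compound 1 to compound 2 (0.11 log units; within the scatter) for moving the nitro group on the sulfonyl aryl ring, showed no such separation, so this is the first change on the shared core with a readable effect. No measurement offered here explains the step.

Still open, as far as these compounds go, is whether an amine or a methoxy group in place of the chlorine would stay close to compound 2 or fall nearer compound 4. Also open, from the compounds shown here alone, is whether the same exchange would have a similar size on compound 1, which carries the 4-nitrophenyl group.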